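The source may hold more compounds than are shown below. What is called first, only, known or untested is meant among the compounds shown, and "the series" means these compounds.

Compound 1 `CCCCNc1nc(N)nc2ccn(CC=C(C)C)c12`: > 25 uM
Compound 2 `CCCCNc1nc(N)nc2ccn(Cc3ccsc3)c12`: > 25 uM

In an assay on HEK293 cells for agonist activity at Toll-like receptor 8 (Homo sapiens), read by a luciferase reporter, with a stated time of 6 h (on this read-out higher numbers stand for an effect only at larger amounts of compound and lower numbers for an effect already at smaller amounts), compound 1 gives > 25 uM, which is a limit of the assay and not a number. Compound 2 gives > 25 uM in this assay, likewise a limit. The step that the two limits leave unreadable from compound 1 to compound 2 is thus not readable, and the limit of > 25 uM in this assay, at which 2 of the 2 values shown sit, is all the evidence there is. Compound 3 `CCCCNc1nc(N)nc2ccn(Cc3ccccn3)c12` differs from compound 2 by pyridin-2-yl in place of thiophen-3-yl on a saturated chain carbon bound to an aromatic nitrogen. Within the data shown here, no measured step bears on this change, and both measured values sit at the limit. The expected step that the limit leaves unreadable from compound 2 to compound 3 is therefore small in either direction. Compound 3 is estimated at 40 uM, within 12 uM to 150 uM, and a further limit is the likeliest outcome.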

Compound 3, minimum effective concentration: > 25 uM
Compound 3: no number, only a limit; the forecaster's own chance of this, stated with the estimate: 70%; the middle value is on the limit's open side.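

Among these compounds, no step among compound 1, compound 2 and compound 3 can be read: the limit of > 25 uM in this assay, at which 3 of the 3 values shown sit. These compounds leave open whether the 2-methylprop-1-en-1-yl, thiophen-3-yl and pyridin-2-yl groups differ at all in their effect on this read-out.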